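Adding a hydroxy to a thiosemicarbazone side chain

A few compounds are considered here, and "the series" means these few. Any claim that something is new, unique, unknown or untested is made for them only; others in the source may bear on it.

The starting point is compound 1 `CC1=CC[C@@H]([C@@](C)(O)CCCC(C)(C)NC=S)CC1`, in which the thiocarbonyl carbon carries only a hydrogen. In a functional assay on HT-29 cells (Homo sapiens) for cytotoxicity, read by sulforhodamine B assay (a higher number here means a weaker inhibitor of growth, a lower number a stronger inhibitor of growth), compound 1 gives 11400 nM. Compound 2 `CC1=CC[C@@H]([C@@](C)(O)CCCC(C)(C)NC(=S)N/N=C\c2ccccc2)CC1` replaces that hydrogen with a larger group ending in a phenyl ring, and compound 2 gives 9960 nM; the step is a 1.1-fold lower number from compound 1 to compound 2 (0.06 log units; within the scatter). Compound 3 `COc1ccc(/C=N\NC(=S)NC(C)(C)CCC[C@](C)(O)[C@@H]2CC=C(C)CC2)cc1` adds a methoxy to that phenyl ring and gives 7420 nM, a step of a 1.3-fold lower number from compound 2 to compound 3 (0.13 log units; within the scatter). Compound 2 has the second highest of the three numbers, but its gaps to compound 1 and to compound 3 both fall within the scatter, so the three compounds cannot be told apart on these data.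

Compound 4 `CC1=CC[C@@H]([C@@](C)(O)CCCC(C)(C)NC(=S)N/N=C\c2ccc(O)cc2)CC1` differs from compound 2 by hydroxy in place of hydrogen on an aromatic carbon, so that the phenyl becomes 4-hydroxyphenyl. Among the compounds with values here, the one measured step that bears on this is the methoxy step from compound 2 to compound 3, which placed a small group on the same ring and stayed within the scatter. A similar small group at the same place is therefore expected to give no step beyond the scatter, and the expected step is a 1.1-fold lower number from compound 2 to compound 4 (0.04 log units; within the scatter). Compound 4 is estimated to give 9000 nM in this assay, with a range from 4500 nM to 18000 nM.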

Compound 4, concentration for 50% growth inhibition: 8150 nM
Compound 4: middle estimate off by 1.1-fold (0.04 log units), on the high side, and the stated range covers the measured number.
By their numbers in this assay, from the lowest: compounds 3, 4, 2 and 1 (each within the scatter of the next).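

In this assay, hydroxy in place of hydrogen on an aromatic carbon, para to a large group, gives a 1.2-fold lower number from compound 2 to compound 4 (0.09 log units; within the scatter) and so cannot be read as a change. Until now only methoxy had been seen on this ring, and hydroxy is a second, different group that also leaves the number within the scatter. Removing the methyl from the oxygen gives a 1.1-fold higher number from compound 3 to compound 4 (0.04 log units; within the scatter) as well, so in these compounds hydrogen, methoxy and hydroxy at this place cannot be told apart, even though the hydroxy brings a hydrogen-bond donor and acceptor to the ring. Nothing in the data speaks to why these steps are so small.

Going by these compounds, whether an amine, a carboxylic acid or a longer chain at this same place would give a step beyond the scatter stays open. The compounds also leave open whether hydroxy elsewhere on the ring would behave as it does here, and whether any change to this ring can move the number in a way that can be read.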